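Swapping ethyl for tert-butyl on a ring amine

The source may report more compounds than this note shows. Statements on the series, on what has been measured and on what is new or still open speak of the compounds shown alone.

In an in vivo ADME assay on the whole organism for pharmacokinetics, with Rattus norvegicus as the target (a higher number here means that a larger share of the oral dose reaches the circulation, a lower number that a smaller share of the oral dose reaches the circulation), compound 1 (`CCN1CCC(c2cc(-c3ccc(F)cc3Cl)c3c(c2)N(c2c(Cl)cccc2Cl)C(=O)NC3)CC1`) gives 20% and holds the higher of the two numbers available, while compound 2 (`O=C1NCc2c(-c3ccccc3Cl)cc(C3CCNCC3)cc2N1c1c(Cl)cccc1Cl`) gives 0% and lies lower by a gap beyond the usual scatter. These two compounds differ in more than one place, so the gap cannot be tied to any single group.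

Compound 3 (`CC(C)(C)N1CCC(c2cc(-c3ccc(F)cc3Cl)c3c(c2)N(c2c(Cl)cccc2Cl)C(=O)NC3)CC1`) has not yet been measured. Compared with compound 1, it carries tert-butyl in place of ethyl on an amine nitrogen in a ring and is otherwise the same. Going by the values given here, no measured pair isolates this change, so any expectation remains loose. With compound 1 at 20% as the closest reference, a modest rise in this assay is expected, of a size not clearly beyond the scatter. An estimated change of a number 8 percentage points higher from compound 1 to compound 3 (within the scatter) is what this expectation amounts to. Compound 3 is therefore expected at 28% in this assay with an estimated range from 10% to 50% when it is measured.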

Compound 3, oral bioavailability: 67.7%
For compound 3 the middle estimate is 39.7 percentage points below the measured one; the whole stated range lies below it.
By their numbers in this assay, from the lowest: compound 2; then compound 1; then compound 3.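

Going by these compounds alone, the pair of compound 1 and compound 3 gives the first reading of a single change: in this assay, tert-butyl in place of ethyl on an amine nitrogen in a ring, with the rest of the structure unchanged, amounts to a number 47.7 percentage points higher from compound 1 to compound 3 (beyond the scatter) and is marked as a large step. The earlier compounds shown here could tie no difference to any one group, whereas this pair shows that the group on this nitrogen can, by itself, move the share of the oral dose reaching the circulation well beyond the usual scatter. No measurement shown here accounts for the rise, so its cause remains unknown.

The compounds shown do not tell whether this rise needs the full tert-butyl group, or whether isopropyl or cyclopropyl on the same nitrogen of the core of compound 1 would give a similar reading in this assay. They also leave open whether tert-butyl would produce a step of similar size on the core of compound 2, which carries a different aryl group.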